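Halogen trimming on the aryl-lactam series

This account rests on a few compounds, and the source may have more. Where it says the series, first, only, none or still open, it means among the compounds named here.

Going by the values given here, compound 2 `O=C1C=CC(OCC(F)(F)F)N1c1ccc(Cl)cc1F` holds the lowest number of the two measured so far: in a functional assay on MDA-MB-231 cells (Homo sapiens) for inhibition (on this read-out higher numbers stand for weaker inhibition and lower numbers for stronger inhibition), compound 2 gives 6100 nM, whereas compound 1 `O=C1C=CC(OCC(F)(F)F)N1c1ccccc1` gives 15300 nM, a gap beyond the scatter. The step to compound 3 `O=C1C=CC(OCC(F)(F)F)N1c1ccccc1F` is hydrogen in place of chloro on an aromatic carbon, meta to a fluoro group and para to a large group. Among the compounds with values here, no measured step of this kind exists. Compound 1 carries neither halogen and sits at 15300 nM; compound 3 keeps the fluoro, so the expected move is toward weaker inhibition, modest and short of compound 1. Compound 3 is expected at 11000 nM (range 5000 nM to 25000 nM), a step of a 1.8-fold higher number from compound 2 to compound 3 (0.26 log units; within the scatter).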

Compound 3, half-maximal inhibitory concentration: 20600 nM
The estimate for compound 3 lay 1.9-fold (0.27 log units) below the measured number; the range from low to high includes it.
By their numbers in this assay, from the lowest: compound 2; then compounds 1 and 3 (each within the scatter of the next).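

With the fluoro in place, the chloro para to a large group counts in this assay: hydrogen in place of chloro gives a 3.4-fold higher number from compound 2 to compound 3 (0.53 log units; beyond the scatter) and weaker inhibition. The fluoro on its own, without the chloro, cannot be told apart from hydrogen, at a 1.3-fold higher number from compound 1 to compound 3 (0.13 log units; within the scatter) on the same read-out. Nothing measured here explains the chloro's contribution.

Open, on these data alone, are the chloro without the fluoro, and whether a bromo, a methoxy group or an amine at this carbon would match or exceed compound 2.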